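The source may hold more compounds than are shown below. What is called first, only, known or untested is meant among the compounds shown, and "the series" means these compounds.

Measured so far:
- compound 1 `CNc1nc(NCCCN(C)C)c2sc(-c3ccc(N4CCNCC4)cc3)cc2n1`: 36 uL/min
- compound 2 `CNc1nc(NCCCN(C)C)c2sc(-c3cccc4cnccc34)cc2n1`: 68.7 uL/min

Working notes on the series. Two compounds sharing the core of compound 1 `CNc1nc(NCCCN(C)C)c2sc(-c3ccc(N4CCNCC4)cc3)cc2n1` have been run in an ADME assay (liver) for metabolic stability, with Liver microsome (Homo sapiens) as the target, read by LC-MS, using microsomes, tested at 1 uM; a lower number here means slower removal, a higher number faster removal of the compound. Compound 1 gives 36 uL/min in this assay, and compound 2 `CNc1nc(NCCCN(C)C)c2sc(-c3cccc4cnccc34)cc2n1` gives 68.7 uL/min. The two numbers sit within the scatter of each other, so nothing separates them with confidence, and compound 1 cannot be called the more stable of the pair. For the measured compounds named here, no pairwise step between measured compounds is available.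

The next compound, compound 3 `CNc1nc(NCCCN(C)C)c2sc(-c3ccccc3)cc2n1`, is not yet measured in this assay. It differs from compound 1 in one place: hydrogen in place of piperazin-1-yl on an aromatic carbon. Going by the values given here, with no measured step to lean on, the size of the change from compound 1 to compound 3 is open; a modest step, most likely toward a higher number, is the working expectation, though a result inside the scatter would not surprise.

Compound 3 is estimated at 55 uL/min in this assay, within a range of 25 uL/min to 120 uL/min, which is expected to correspond to a step of a 1.5-fold higher number from compound 1 to compound 3 (0.18 log units; within the scatter).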

Compound 3, intrinsic clearance in a liver preparation (reported as CLH), per the amount of preparation that the assay uses in the Liver microsome assay: 5 uL/min
Beside the measured number, compound 3's estimate is 11-fold (1.04 log units) above it; measured number below the stated range.
By their numbers in the Liver microsome assay, from the lowest: compound 3; then compounds 1 and 2 (each within the scatter of the next).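

For the compounds shown here, on this position of the aromatic ring, the earlier compounds offered no pairwise step, whereas here replacing piperazin-1-yl with hydrogen gives in the Liver microsome assay a 7.2-fold lower number from compound 1 to compound 3 (0.86 log units; beyond the scatter), so the number clearly responds to the group at this place, and compound 3 now stands apart from compound 1 beyond the scatter. The same change also registers in a second read-out: in a physicochemical assay for solubility, in phosphate buffer, at pH 6.5 (a higher number here means a more soluble compound, a lower number a less soluble compound), compound 1 gives 12.5 ug/mL, and the step is an at least 8.0-fold higher number from compound 1 to compound 3 (0.90 log units; beyond the scatter), so both read-outs move with this one change, and in the direction of a better profile in each. In the physicochemical assay compound 3 gives > 100 ug/mL, which is a limit of the assay and not a number, so the true size of this step stays unknown: the limit of > 100 ug/mL in the physicochemical assay, at which 1 of the 2 values shown sits.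

The compounds shown leave open where a morpholin-4-yl ring, a small amine such as dimethylamino, or a hydroxyl group at this position would fall relative to hydrogen and piperazin-1-yl in both assays. Which part of the piperazin-1-yl group carries the step also stays open, with only the whole group and hydrogen compared.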